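The source may hold more compounds than are shown below. What is called first, only, known or untested is meant among the compounds shown, and "the series" means these compounds.

Working notes on the series. Compound 1 `CN1CCC(OC(=O)c2ccccc2Oc2ccccc2)CC1` and compound 2 `CCOc1ccccc1C(=O)OC1CCN(C)CC1` share one core; in a functional assay on the whole organism with Mus musculus as the target (a lower number here means a less potent compound, a higher number a more potent compound, by a factor of ten per unit of this negative logarithm), compound 1 gives 1.24 and compound 2 gives 1.18. Within the data shown here, the single measured step, a number 0.06 log units lower from compound 1 to compound 2 (within the scatter), covers ethyl in place of phenyl on an oxygen on an aromatic ring. On the two numbers shown compound 2 stands lowest, with compound 1 within the scatter of it. Compound 3 `CCc1ccccc1C(=O)OC1CCN(C)CC1` is not yet measured; it differs from compound 2 by ethyl in place of ethoxy on an aromatic carbon. The step from compound 1 to compound 2 bears on this only loosely, the oxygen itself now leaving, and it was within the scatter, so no step beyond the scatter is expected, a number 0.03 log units lower from compound 2 to compound 3 (within the scatter). Compound 3 is estimated in this assay at 1.15, range 0.7 to 1.6.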

Compound 3, logarithm of the reciprocal of the active concentration, log(1/C): 1.15
Compound 3: middle estimate and measured number agree at the digits printed; measured number inside the range.
By their numbers in this assay, from the lowest: compounds 3, 2 and 1 (each within the scatter of the next).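

In this assay the oxygen on this aromatic carbon can leave with no step beyond the scatter: ethyl in place of ethoxy gives (a number 0.03 log units lower from compound 2 to compound 3 (within the scatter)), and ethyl in place of phenoxy gives (a number 0.09 log units lower from compound 1 to compound 3 (within the scatter)). The earlier step changed only the group on the oxygen, whereas these two remove the oxygen itself, and the three compounds still cannot be told apart at this position. Nothing available gives a reason for this. Still open, as far as these compounds go, is whether an amine, a carboxylic acid or a longer chain on this aromatic carbon would give a step beyond the scatter.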